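The source may report more compounds than this note shows. Statements on the series, on what has been measured and on what is new or still open speak of the compounds shown alone.

Of the compounds shown here, two have so far been measured in a physicochemical assay for lipophilicity, read by HPLC, measured as octanol-water partition, at pH 7.4; a lower number here means a more polar compound, a higher number a more lipophilic compound. Compound 1 `NC(=O)[C@@H](CCC(F)(F)F)N(C[C@H]1CCCCO1)S(=O)(=O)c1ccc(Cl)cc1` gives 4.3, and compound 2 `NC(=O)[C@@H](CCC(F)(F)F)N(C[C@@H]1CCCOC1)S(=O)(=O)c1ccc(Cl)cc1` gives 3.7, the lower of the two numbers. Compound 3 `NC(=O)[C@@H](CCC(F)(F)F)N(C[C@@H]1CCOC1)S(=O)(=O)c1ccc(Cl)cc1` is still unmeasured and differs from compound 2 on a saturated chain carbon bound to a sulfonamide nitrogen: oxolan-3-yl in place of oxan-3-yl on a saturated chain carbon bound to a sulfonamide nitrogen. Oxolan-3-yl thus stands in place of oxan-3-yl, and the six-membered non-aromatic ring gives way to a five-membered one. Among the compounds with values here, only one measured step bears on this, and only indirectly: a number 0.60 log units lower from compound 1 to compound 2 (beyond the scatter), the exchange of oxan-2-yl for oxan-3-yl at that same place. Within the data shown here, no measured pair shows a change of ring size, so the guidance is thin. A modest fall in this assay is nevertheless expected, with an estimated step of a number 0.40 log units lower from compound 2 to compound 3 (beyond the scatter). Compound 3 is estimated at 3.3, with an expected range of 3 to 3.7.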

Compound 3, distribution coefficient: 2.8
For compound 3 the middle estimate is 0.50 log units above the measured one, and the stated range ends above it.
By their numbers in this assay, from the lowest: compound 3; then compound 2; then compound 1.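

In this assay, this place on a saturated chain carbon bound to a sulfonamide nitrogen responds to a change of ring size as well as to a change in where the ring is attached: oxolan-3-yl in place of oxan-3-yl gives a number 0.90 log units lower from compound 2 to compound 3 (beyond the scatter). Oxolan-3-yl in place of oxan-2-yl gives a number 1.50 log units lower from compound 1 to compound 3 (beyond the scatter), the only step here graded large, so the three ring groups at this one place spread widely in this read-out. No evidence given here accounts for the size of either step.

The compounds shown leave open whether an oxetane ring at this place would continue the same direction. They also leave open how a pyrrolidine ring, carrying an amine in place of the ring oxygen, would read.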